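The source may hold more compounds than are shown below. What is called first, only, known or untested is meant among the compounds shown, and "the series" means these compounds.

Compound 3 `CCCc1nc(-c2ccccc2)c(CNCCCN2CCN(c3cccc(C)c3C)CC2)o1` was tested in an assay on HEK293 cells for inhibition of Voltage-dependent T-type calcium channel subunit alpha-1G (Homo sapiens), read by fluorescence, tested at 10 uM (on this read-out higher numbers stand for more inhibition at the one concentration tested (going by the name of the read-out) and lower numbers for less inhibition), where compound 3 gives 55.2%. Its two companions share the same core: compound 1 `CCCc1nc(-c2ccccc2)c(CNCCN2CCN(c3ccc(C)cc3)CC2)o1` gives 48.1% and compound 2 `CCCc1nc(-c2ccccc2)c(CNCCN2CCN(c3ccc(OC)cc3)CC2)o1` gives 51.5%. Among the compounds with values here, the only single-point step among the three is a number 3.4 percentage points higher from compound 1 to compound 2 (within the scatter). Compound 3 holds the largest of the three numbers, yet its gaps to compound 2 and to compound 1 both lie within the usual scatter, so the three cannot be told apart on this read-out.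

Compound 4 `CCCc1nc(-c2ccccc2)c(CNCCCN2CCN(c3ccc(C)c(C)c3)CC2)o1` differs from compound 3 in one place: 3,4-dimethylphenyl in place of 2,3-dimethylphenyl on an amine nitrogen in a ring. Within the data shown here, no measured step rearranges the methyl groups on that aromatic ring; the one step available concerns a methoxy in place of methyl and was itself within the scatter, and compound 1 and compound 3 differ in two places at once, so their values alone say nothing about this change. On this basis no step beyond the scatter is expected for compound 4, and its value in this assay is estimated at 54% with a range from 38% to 70%, which means an expected step of a number 1.2 percentage points lower from compound 3 to compound 4 (within the scatter).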

Compound 4, a percentage reported as inhibition, at one concentration (the size of the read-out at that concentration, not a potency): 54.6%
For compound 4 the middle estimate is 0.6 percentage points below the measured one, and the stated range covers the measured number.
By their numbers in this assay, from the lowest: compounds 1, 2, 4 and 3 (each within the scatter of the next).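

In this assay, putting 3,4-dimethylphenyl in place of 2,3-dimethylphenyl on an amine nitrogen in a ring gives a number 0.6 percentage points lower from compound 3 to compound 4 (within the scatter). This is the only step shown that rearranges the methyl groups on this aromatic ring, and it shows that these two arrangements cannot be told apart on this read-out, at least with the rest of the structure as in compound 3. Nothing available bears on why the two arrangements read alike.

The compounds shown leave open whether a different group on this aromatic ring, such as chlorine or trifluoromethyl, would give a step beyond the scatter. Within the data shown here, they also leave open what a longer chain would do when it is the only change from compound 3.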